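The source may hold more compounds than are shown below. What is called first, only, known or untested is meant among the compounds shown, and "the series" means these compounds.

Compound 3 `COc1cc(F)ccc1N1CCN(CCCNc2c(C(=O)N(C)C)cnc3c(C#N)cccc23)CC1` gives the highest of the three numbers in a functional assay on aorta for antagonist activity at Alpha-1D adrenergic receptor (Rattus norvegicus) (a lower number here means tighter binding, a higher number weaker binding), at 398 nM. Compound 2 `COc1cc(F)ccc1N1CCN(CCCNc2c(C(=O)N(C)C)cnc3c(C)cccc23)CC1` sits nearest to it with 316 nM, and compound 1 `CN(C)C(=O)c1cccnc1NCCCN1CCN(c2ccccc2)CC1` lies furthest away with 15.9 nM. Compound 4 `COc1cc(F)ccc1N1CCN(CCCNc2c(C(=O)N(C)C)cnc3c(C(N)=O)cccc23)CC1` differs from compound 3 by carbamoyl in place of cyano on an aromatic carbon. For the measured compounds named here, the one measured step that bears on this change, a 1.3-fold higher number from compound 2 to compound 3 (0.10 log units; within the scatter), lay within the scatter. Going by the values given here, no measured step exchanges a cyano for a carbamoyl, so the expectation for compound 4 rests on that small step alone and is for no movement beyond the scatter, a 1.0-fold higher number from compound 3 to compound 4 (0.00 log units; within the scatter). Compound 4 is therefore estimated at 400 nM in this assay, with a range from 150 nM to 1100 nM.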

Compound 4, dissociation constant: 158 nM
Estimate against measurement, compound 4: 2.5-fold (0.40 log units) above; the range from low to high includes it.
By their numbers in this assay, from the lowest: compound 1; then compounds 4, 2 and 3 (each within the scatter of the next, the first and the last beyond it).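

On this aromatic carbon, ortho to a fused ring, the swap of methyl for cyano had stayed within the scatter, but in this assay the position proves responsive to carbamoyl in place of cyano, with a 2.5-fold lower number from compound 3 to compound 4 (0.40 log units; beyond the scatter). Set against methyl, the same group gives a 2.0-fold lower number from compound 2 to compound 4 (0.30 log units; within the scatter), which stays within the scatter, so only the step from the nitrile stands out. No evidence is available that would explain this step. Going by these compounds, whether an amine or a carboxylic acid on this carbon would match carbamoyl remains open, as does whether the step would recur on the core of compound 1.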